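The source may report more compounds than this note shows. Statements on the series, on what has been measured and on what is new or still open speak of the compounds shown alone.

Within the data shown here, compound 1 `Cc1n[nH]c2ccc(-c3nc4cnc(N5CCN(C)CC5)cn4c3Nc3ccc(Cl)cc3)cc12` carries a 4-chlorophenyl on the aromatic nitrogen of a shared core, and in a functional assay on CWR22R cells (Homo sapiens) for inhibition, with a stated time of 120 h, tested at 10 uM (on this read-out lower numbers stand for less inhibition and higher numbers for more inhibition at the one concentration tested (going by the name of the read-out)), compound 1 gives 8.11%, the only number. Compound 2 `Cc1n[nH]c2ccc(-c3nc4cnc(N5CCN(C)CC5)cn4c3Nc3ccc(Br)cc3Cl)cc12` belongs to the same series, but in this assay compound 2 has "not determined" (no result reported), so no result was reported for it. The present step changes the group on the nitrogen, giving compound 3 `Cc1n[nH]c2ccc(-c3nc4cnc(N5CCN(C)CC5)cn4c3Nc3cc(Cl)ccc3Cl)cc12`. The change is 2,5-dichlorophenyl in place of 4-chlorophenyl on a nitrogen on an aromatic ring. Among the measured compounds shown here, since only one measured value stands in this assay, there is no comparable step to lean on; a single measurement at one concentration that shows little inhibition gives no reason to expect a shift that goes beyond the usual scatter. Compound 3 is therefore expected to give about 12%, somewhere between 0% and 35%. This expectation means a step of a number 3.9 percentage points higher from compound 1 to compound 3 (within the scatter), which lies within the scatter.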

Compound 3, a percentage reported as inhibition, at one concentration (the size of the read-out at that concentration, not a potency): 3.8%
Compound 3: the middle estimate sits 8.2 percentage points above what was measured; the range from low to high includes it.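

In this assay, placing 2,5-dichlorophenyl where compound 1 has 4-chlorophenyl gives a number 4.3 percentage points lower from compound 1 to compound 3 (within the scatter) on the same shared core. Among these compounds, this is the first comparison at this position on the nitrogen, and it shows that this change, which adds one chlorine and keeps the six-membered aromatic ring, does not separate the two compounds in this read-out. Both compounds show little inhibition at the one concentration tested, and nothing available here offers an explanation for the result.

Still open, on these data alone, is whether any group at this position can move the read-out beyond the usual scatter, for example a phenyl carrying an amine or a carboxylic acid. These two compounds also cannot show how inhibition would change at other concentrations.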